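The compounds below may be only part of what the source reports. "The series", "measured", "known", "first", "only" and "open" are said of these compounds alone.

Measured compounds:
- compound 1 `O=C(/C=C/c1ccc2c(c1)B(O)OC2)c1ccc(F)cc1`: in a functional assay on MDA-MB-231 cells (Homo sapiens) for cytotoxicity, read by MTT assay, with a stated time of 48 h (a higher number here means a weaker inhibitor, a lower number a stronger inhibitor), compound 1 gives 1600 nM
- compound 2 `Nc1ccc(C(=O)/C=C/c2ccc3c(c2)B(O)OC3)cc1`: in this assay compound 2 gives 25800 nM

Among the compounds with values here, compound 2 stands at the higher of the two numbers; the only measured step, a 16-fold higher number from compound 1 to compound 2 (1.21 log units; beyond the scatter), separates it from compound 1.

Compound 3 `Nc1cccc(C(=O)/C=C/c2ccc3c(c2)B(O)OC3)c1` differs from compound 2 as follows: 3-aminophenyl in place of 4-aminophenyl on a carbonyl carbon. Within the data shown here, no measured pair shows what moving the amino group within the aminophenyl ring does; the one step on record, a 16-fold higher number from compound 1 to compound 2 (1.21 log units; beyond the scatter), exchanges fluoro for amino and so does not bear on a positional change alone. The shared core and the enone linker are untouched. With nothing in the data pointing either way, the expectation for this assay is a step no larger than the scatter, a 1.3-fold lower number from compound 2 to compound 3 (0.11 log units; within the scatter), and the estimate for compound 3 is 20000 nM, within 7000 nM to 60000 nM.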

Compound 3, half-maximal inhibitory concentration: 3200 nM
Estimate against measurement, compound 3: 6.3-fold (0.80 log units) above; measured number below the stated range.
By their numbers in this assay, from the lowest: compounds 1 and 3 (each within the scatter of the next); then compound 2.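

In this assay the change from 4-aminophenyl to 3-aminophenyl on a carbonyl carbon gives an 8.1-fold lower number from compound 2 to compound 3 (0.91 log units; beyond the scatter) and so shows that the place of the amino group alone moves the number beyond the scatter, which the earlier step from fluoro to amino could not separate. The change from 4-fluorophenyl to 3-aminophenyl gives a 2.0-fold higher number from compound 1 to compound 3 (0.30 log units; within the scatter) and stays within the scatter, so an amino group on this ring does not by itself bring the high number of compound 2. No measurement at hand accounts for this dependence on position.

As far as these compounds go, whether fluoro responds to the same move as amino remains open. Also open, from the compounds shown here alone, is whether a hydroxyl or a methoxy group in place of the amino group of compound 3 would keep its number.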